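A few compounds are considered here, and "the series" means these few. Any claim that something is new, unique, unknown or untested is made for them only; others in the source may bear on it.

Of the compounds shown here, two have so far been measured in a functional assay on SR cells (Homo sapiens) for cytotoxicity, read by sulforhodamine B assay, with a stated time of 48 h, tested at 1 uM; on this read-out higher numbers stand for a weaker effect at the one concentration tested and lower numbers for a stronger effect. Compound 1 `COc1cc(-c2cc(/C=C/C(=O)c3ccc(N)cc3)[nH]n2)cc(OC)c1OC` gives 14%, the lowest of the two numbers. Within the data shown here, compound 2 `COc1ccc(-c2cc(/C=C/C(=O)c3ccc(N)cc3)[nH]n2)cc1OC` gives 34%; the single measured step, a number 20 percentage points higher from compound 1 to compound 2 (beyond the scatter), separates them, and it concerns a methoxy group on the aromatic ring attached to the shared core. Compound 3 `COc1ccc(C(=O)/C=C/c2cc(-c3cc(OC)c(OC)c(OC)c3)n[nH]2)cc1OC` has not yet been measured. It differs from compound 1 in this way: 3,4-dimethoxyphenyl in place of 4-aminophenyl on a carbonyl carbon. Among the measured compounds shown here, that change is on the carbonyl carbon, a different part of the molecule from the one altered in the measured step, so no measured step bears directly on it, and the direction of the effect is open. Compound 3 is therefore expected, with wide uncertainty, to give about 35%, somewhere between 10% and 75%, which would mean an estimated step of a number 21 percentage points higher from compound 1 to compound 3 (beyond the scatter).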

Compound 3, a percentage reported as activity, at one concentration (the size of the read-out at that concentration, not a potency): 11%
For compound 3 the middle estimate is 24 percentage points above the measured one; measured number inside the range.
By their numbers in this assay, from the lowest: compounds 3 and 1 (each within the scatter of the next); then compound 2.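

In this assay, the step on the carbonyl carbon is a number 3 percentage points lower from compound 1 to compound 3 (within the scatter), so the two compounds cannot be told apart. Among these compounds, this is the first measured change at this position, and it shows that 4-aminophenyl is not needed there for a strong effect at the one concentration tested: 3,4-dimethoxyphenyl, a larger group with no hydrogen-bond donor, does as well on the core of compound 1. Nothing available explains why these two groups read alike.

As far as these compounds go, it remains open whether the position accepts almost any aromatic group or only some, as a 4-hydroxyphenyl, a plain phenyl or a 4-carboxyphenyl on the carbonyl carbon would show. From the compounds shown here alone, it is also open whether 3,4-dimethoxyphenyl would read the same way on the core of compound 2.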